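A Second Methoxy on the Sulfonamide Phenyl Ring

The compounds below may be only part of what the source reports. "The series", "measured", "known", "first", "only" and "open" are said of these compounds alone.

Measured so far:
compound 1 `CN(c1ccc2[nH]c(-c3n[nH]c4ccccc34)cc2n1)S(=O)(=O)c1ccccc1` gives 12000 nM in a functional assay on SMMC-7721 cells (Homo sapiens) for antiproliferative activity, read by MTT assay, with a stated time of 72 h; on this read-out higher numbers stand for weaker inhibition and lower numbers for stronger inhibition
compound 2 `COc1ccc(S(=O)(=O)N(C)c2ccc3[nH]c(-c4n[nH]c5ccccc45)cc3n2)cc1` gives 13000 nM in this assay

Compound 2 carries one methoxy more than compound 1, and that step, a 1.1-fold higher number from compound 1 to compound 2 (0.03 log units; within the scatter), stayed within the scatter, so compound 2 sits alongside compound 1 rather than apart from it. Compound 3 `COc1ccc(S(=O)(=O)N(C)c2ccc3[nH]c(-c4n[nH]c5ccccc45)cc3n2)cc1OC` adds (methoxy in place of hydrogen on an aromatic carbon), ortho to a methoxy group and meta to a large group, turning 4-methoxyphenyl into 3,4-dimethoxyphenyl. For the measured compounds named here, the only step that bears on this is a 1.1-fold higher number from compound 1 to compound 2 (0.03 log units; within the scatter), which moved nothing beyond the scatter, so no change beyond the scatter is expected in this assay. Compound 3 is therefore expected near 14000 nM, between 6000 nM and 35000 nM, meaning a 1.1-fold higher number from compound 2 to compound 3 (0.03 log units; within the scatter).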

Compound 3, half-maximal inhibitory concentration: 26600 nM
Beside the measured number, compound 3's estimate is 1.9-fold (0.28 log units) below it, and the stated range covers the measured number.
By their numbers in this assay, from the lowest: compounds 1 and 2 (each within the scatter of the next); then compound 3.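

Adding a first methoxy left the number within the scatter, but the second, ortho to a methoxy group, gives the first step beyond it in this assay, with a 2.0-fold higher number from compound 2 to compound 3 (0.31 log units; beyond the scatter) toward weaker inhibition. The full change from phenyl to 3,4-dimethoxyphenyl reads a 2.2-fold higher number from compound 1 to compound 3 (0.35 log units; beyond the scatter) and is also modest, so this ring accepts both groups with only a small loss. Nothing available here explains this step.

Going by these compounds, whether this small loss is particular to methoxy remains open. An amine, a carboxylic acid or a longer chain in the same place could answer that.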